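A few compounds are considered here, and "the series" means these few. Any claim that something is new, unique, unknown or untested is made for them only; others in the source may bear on it.

Measured so far in an ADME assay on MDBK cells (Bos taurus) for cytotoxicity, read by MTT assay, with a stated time of 96 h; on this read-out lower numbers stand for higher toxicity in this test and higher numbers for lower toxicity in this test:
Compound 1 `FC(F)(F)c1cccc(NC(=S)Nc2cccc(Br)c2)c1` gives 10000 nM.
Compound 2 `FC(F)(F)c1cccc(NC(=S)Nc2ccccc2Br)c1` gives > 100000 nM, which is a limit of the assay and not a number.
Compound 3 `FC(F)(F)c1cccc(NC(=S)Nc2ccccc2)c1` gives 49000 nM.

Compound 3 stands highest of the two numbers shown; its nearest neighbour is compound 1, and that step reads a 4.9-fold higher number from compound 1 to compound 3 (0.69 log units; beyond the scatter). Set against compound 2 the comparison reads an at least 2.0-fold lower number from compound 2 to compound 3 (0.30 log units; that floor lies within the scatter), its floor within the scatter. Compound 4 `Fc1cccc(NC(=S)Nc2cccc(C(F)(F)F)c2)c1` differs from compound 3 by fluoro in place of hydrogen on an aromatic carbon, placed on an aromatic carbon of a six-membered aromatic ring of carbon only, meta to a large group. The step that bears on this change is a 4.9-fold higher number from compound 1 to compound 3 (0.69 log units; beyond the scatter), where hydrogen in place of bromo on an aromatic carbon raised the number beyond the scatter; the step from compound 3 to compound 4 runs the other way. Fluoro is not bromo, so the full size of that step is not assumed, and a lowering of modest size is expected. Compound 4 is estimated to give 30000 nM, between 12000 nM and 80000 nM. The expected step is a 1.6-fold lower number from compound 3 to compound 4 (0.21 log units; within the scatter).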

Compound 4, half-maximal cytotoxic concentration: 10000 nM
Compound 4: the middle estimate sits 3.0-fold (0.48 log units) above what was measured, and the stated range ends above it.
By their numbers in this assay, from the lowest: compounds 1 and 4 (each within the scatter of the next); then compound 3. At a limit, above all of these: compound 2.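

In this assay, fluoro in place of hydrogen on an aromatic carbon, meta to a large group, gave a 4.9-fold lower number from compound 3 to compound 4 (0.69 log units; beyond the scatter), so one added fluorine atom is enough to move the number beyond the scatter. Fluoro in place of bromo gave no change at the digits printed from compound 1 to compound 4 (within the scatter), which shows that the 3-fluorophenyl and 3-bromophenyl compounds cannot be told apart in this test. 3-Fluorophenyl in place of 2-bromophenyl gave an at least 10-fold lower number from compound 2 to compound 4 (1.00 log units; beyond the scatter), but that step is only a floor, since the value of compound 2 is a limit of the assay: the limit of > 100000 nM in this assay, at which 1 of the 4 values shown sits.

On these data alone, whether any substituent at this place would lower the number as fluoro and bromo do stays open, and a chloro, methoxy or amine group there could test that. What lies behind the shift also remains unknown.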